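Chloro to Trifluoromethyl on the Urea Aryl Ring

The source may report more compounds than this note shows. Statements on the series, on what has been measured and on what is new or still open speak of the compounds shown alone.

Compound 1 `COc1cc(-c2nn(-c3cccc(NC(=O)Nc4ccc(Cl)c(Cl)c4)c3)cc2-c2ccncc2)ccc1Cl`: > 50000 nM, a limit.
Compound 2 `O=C(Nc1cccc(-n2cc(-c3ccncc3)c(-c3ccc(Cl)c(O)c3)n2)c1)Nc1ccc(Cl)c(Cl)c1`: > 32500 nM, a limit.

In a functional assay on NCI-H322M cells (Homo sapiens) for inhibition, read by sulforhodamine B assay, with a stated time of 48 h (on this read-out higher numbers stand for weaker inhibition of growth and lower numbers for stronger inhibition of growth), compound 1 gives > 50000 nM, which is a limit of the assay and not a number. Compound 2 also gives only a limit, > 32500 nM. The step that the two limits leave unreadable from compound 1 to compound 2 is therefore unreadable; compound 1 sits at the limit of > 50000 nM in this assay, at which 1 of the 2 values shown sits, and compound 2 at the limit of > 32500 nM in this assay, at which 1 of the 2 values shown sits. Compound 3 `COc1cc(-c2nn(-c3cccc(NC(=O)Nc4ccc(Cl)c(C(F)(F)F)c4)c3)cc2-c2ccncc2)ccc1Cl` differs from compound 1 by trifluoromethyl in place of chloro on an aromatic carbon. Among the compounds with values here, no measured step bears on this change, so compound 3 is expected to stay at a limit as well, with a number no higher from compound 1 to compound 3 (the limit leaves the size open) meaning no readable step. The estimate for compound 3 is 50000 nM (range 20000 nM to 100000 nM).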

Compound 3, concentration for total growth inhibition: 13900 nM
Compound 3: middle estimate off by 3.6-fold (0.56 log units), on the high side, outside the stated range (below it).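

Within the data shown here, on the urea aryl ring, trifluoromethyl in place of chloro gives the first readable change here: an at least 3.5-fold lower number from compound 1 to compound 3 (0.55 log units; beyond the scatter) in this assay. This shows that growth inhibition responds to the group at this carbon, ortho to a chloro group, whereas the step between compound 1 and compound 2 cannot be read. The true size of the new step stays open because compound 1 gives only a limit: the limit of > 50000 nM in this assay, at which 1 of the 3 values shown sits.

The compounds shown test only one replacement for chloro at this carbon. On these data alone, how a nitrile or an amine there would read remains open.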